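The source may hold more compounds than are shown below. What is called first, only, known or untested is meant among the compounds shown, and "the series" means these compounds.

Measured so far in an ADME assay on J774 cells (Mus musculus) for cytotoxicity (a higher number here means that more compound is needed for the effect, a lower number that less compound is needed), all three values being limits of the assay rather than numbers:

- Compound 1 `COC(=O)c1c[nH]c2cc(OCCOc3ccccc3)c(Cl)cc2c1=O`: > 20000 nM
- Compound 2 `COC(=O)c1c[nH]c2cc(OCCOc3ccccc3)c(C)cc2c1=O`: > 20000 nM
- Compound 3 `CCCc1cc2c(=O)c(C(=O)OC)c[nH]c2cc1OCCOc1ccccc1`: > 20000 nM

Compound 3 has only a limit, > 20000 nM. It shares this position with the other two compounds: the limit of > 20000 nM in this assay, at which 3 of the 3 values shown sit.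

Compound 4 `COC(=O)c1c[nH]c2cc(OCCOc3ccccc3)c(Br)cc2c1=O` is the next to consider, and it differs from compound 3 by one change: bromo in place of propyl on an aromatic carbon. In short, bromo replaces propyl.

Among the compounds with values here, three measured steps bear on this, all changing the group at that same place or the chain on it: a step that the two limits leave unreadable from compound 1 to compound 2, a step that the two limits leave unreadable from compound 1 to compound 3 and a step that the two limits leave unreadable from compound 2 to compound 3. None of them gives a size. Chloro, methyl and propyl all leave the compounds at the same limit, so no step beyond the scatter is expected in this assay, and a further limit is the likeliest report. The expected step is a number no higher from compound 3 to compound 4 (the limit leaves the size open). For compound 4 the estimated value is 20000 nM, with an expected range from 10000 nM to 40000 nM.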

Compound 4, half-maximal effective concentration: > 20000 nM
Compound 4 was reported as a limit; the forecaster's own chance of this, stated with the estimate: 85%; the middle value sits exactly at the limit.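

No step from compound 1, compound 2 or compound 3 to compound 4 can be read in this assay, where each compound has only a limit: the limit of > 20000 nM in this assay, at which 4 of the 4 values shown sit.

The compounds shown leave open whether chloro, methyl, propyl and bromo differ at all in this assay, as none of the four has an actual number.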